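This account rests on a few compounds, and the source may have more. Where it says the series, first, only, none or still open, it means among the compounds named here.

Measured compounds:
- compound 1, `CC(C)S(=O)(=O)Nc1cccc2c1CCCC2c1c[nH]cn1` — 2040 nM in an assay on isolated protein for binding affinity to Alpha-1D adrenergic receptor (Rattus norvegicus), read by radioligand binding; on this read-out lower numbers stand for stronger inhibition and higher numbers for weaker inhibition
- compound 2, `CN(C)S(=O)(=O)Nc1cccc2c1CCCC2c1c[nH]cn1` — 1580 nM in this assay

Compound 1 and compound 2 share one core and differ only in the group on the sulfonyl sulfur. Among the measured compounds shown here, the one measured step between them, a 1.3-fold lower number from compound 1 to compound 2 (0.11 log units; within the scatter), is within the scatter, so the two values cannot be told apart. Compound 2 holds the lowest of the two numbers, but its nearest neighbour, compound 1, sits within the scatter of it, so this is no ranking.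

Compound 3, `Nc1cccc2c1CCCC2c1c[nH]cn1`, goes further: hydrogen in place of dimethylsulfamoyl on a nitrogen on an aromatic ring. The whole sulfamoyl group is gone and a plain amino group remains. For the measured compounds named here, no measured step covers such a removal; the only step on record, a 1.3-fold lower number from compound 1 to compound 2 (0.11 log units; within the scatter), swaps one group on the sulfonyl sulfur for another and leaves the sulfonamide in place. It therefore tells little about compound 3, except that two rather different groups on that sulfur gave the same outcome.

Going by the values given here, with no guiding step, the expected step is a 1.3-fold higher number from compound 2 to compound 3 (0.10 log units; within the scatter), that is, none beyond the scatter, but with wide uncertainty. For compound 3 the estimate in this assay is 2000 nM, expected between 500 nM and 8000 nM.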

Compound 3, inhibition constant: 191 nM
Compound 3: the middle estimate sits 10-fold (1.02 log units) above what was measured; the whole stated range lies above it.
By their numbers in this assay, from the lowest: compound 3; then compounds 2 and 1 (each within the scatter of the next).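

In this assay the plain amino group of compound 3 stands apart from both sulfonamides, with an 8.3-fold lower number from compound 2 to compound 3 (0.92 log units; beyond the scatter) and an 11-fold lower number from compound 1 to compound 3 (1.03 log units; beyond the scatter) as the two steps. The earlier swap of isopropyl for dimethylamino on the sulfur made no difference that could be told from the scatter, whereas removing the whole sulfonyl-bearing group from the nitrogen does, so for these three compounds the presence of that group counts for more than the choice between those two substituents on its sulfur. Nothing measured here explains why the number falls when the group leaves.

The compounds shown leave open how much of the removed group has to go, since each of them carries either a complete sulfonamide or none at all, and a smaller group on the same nitrogen, such as methylsulfonyl or acetyl, would sit between those extremes. They also leave open whether the free amino group itself is best at this position, which a methylamino or dimethylamino group directly on the ring in its place would begin to test.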